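Branched carbamates at the glucose-dependent insulinotropic receptor

The source may hold more compounds than are shown below. What is called first, only, known or untested is meant among the compounds shown, and "the series" means these compounds.

Measured so far:
compound 1 `CC(C)OC(=O)N1CCC(Oc2cccc3c2CCN3c2ccc(S(C)(=O)=O)cc2)CC1` gives 70% in a functional assay on CHO-K1 cells with Glucose-dependent insulinotropic receptor (Homo sapiens) as the target, read by a luciferase reporter, with a stated time of 5 h; on this read-out lower numbers stand for smaller maximal responses and higher numbers for larger maximal responses;
compound 2 `CC(C)(C)OC(=O)N1CCC(Oc2cccc3c2CCN3c2ccc(S(C)(=O)=O)cc2)CC1` gives 92% in this assay;
compound 3 `CC(C)COC(=O)N1CCC(Oc2ncnc3c2CCN3c2ccc(S(C)(=O)=O)cc2F)CC1` gives 94% in this assay.

All three share a piperidine carbamate and differ in the carbamate's alkyl group and in the core. From compound 1 to compound 2 the change is methyl in place of hydrogen on a saturated chain carbon bound to an oxygen next to a carbonyl group and two saturated chain carbons, and this assay moves by a number 22 percentage points higher from compound 1 to compound 2 (beyond the scatter). Compound 3 stands at the top of the three values; its gap to compound 2 is within the usual scatter, its gap to compound 1 beyond it. The difference between the cores of compound 1 and compound 3 is not broken down here.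

Compound 4 `CC(C)(C)COC(=O)N1CCC(Oc2ncnc3c2CCN3c2ccc(S(C)(=O)=O)cc2F)CC1` has not yet been measured. It differs from compound 3 by methyl in place of hydrogen on a saturated chain carbon bound to three saturated chain carbons, the same kind of change as from compound 1 to compound 2, though here the carbon carries three saturated chain carbons rather than an oxygen next to a carbonyl group. The earlier step was modest, and compound 3 already gives 94%, so little room remains; a step of about a number 1 percentage points higher from compound 3 to compound 4 (within the scatter) is expected. Compound 4 is estimated at 95% in this assay.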

Compound 4, largest response reached (reported as percent of maximum), in percent of the reference or control that the assay uses: 80%
Estimate against measurement, compound 4: 15 percentage points above; the whole stated range lies above it.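

In this assay, swapping isobutyl for neopentyl on the carbamate gives a number 14 percentage points lower from compound 3 to compound 4 (beyond the scatter), so a methyl added to a branched carbamate group raises the maximal response in one pair and lowers it in the other. Within the data shown here, in this series, then, the effect of this kind of change cannot be assumed to carry from one core to another, and the two steps clearly differ: the same change on two cores in this assay, a number 22 percentage points higher (beyond the scatter) from compound 1 to compound 2 and a number 14 percentage points lower (beyond the scatter) from compound 3 to compound 4, 36 percentage points apart, beyond the scatter of two such steps What this does not show is that the core alone sets the direction, since the methyl also lands on a different carbon in each pair, one bound to the carbamate oxygen and the other bound to three saturated chain carbons, and each core offers only a single pair.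

The isobutyl and neopentyl carbamates on the core of compound 1, and the isopropyl and tert-butyl carbamates on the core of compound 3, would separate these two differences, and the compounds shown leave that comparison open. Also open, going by these compounds, is how a cyclopropyl or cyclobutyl group on the carbamate would behave on either core.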